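Methyl on the benzoxazole of compound 3

This account rests on a few compounds, and the source may have more. Where it says the series, first, only, none or still open, it means among the compounds named here.

Among the measured compounds shown here, compound 3 `C[C@@H](Cc1ccc2ocnc2c1)CN1C[C@@H]2CCCC[C@@H]2[C@H](C(=O)N2CCN(c3ccc(F)c(F)c3)CC2)C1` gives 1620 nM in an assay on isolated protein for binding affinity to somatostatin receptor type 1 (Homo sapiens) (on this read-out higher numbers stand for weaker binding and lower numbers for tighter binding), the highest of the three numbers so far. Compound 1 `COC(=O)c1cc(CC(C)CN2CC3CCCCC3C(C(=O)N3CCN(c4ccc([N+](=O)[O-])cc4)CC3)C2)cc(C(=O)OC)c1` gives 1000 nM, which lies within the scatter of compound 3. Compound 2 `COC(=O)c1cc(C[C@@H](C)CN2C[C@@H]3CCCC[C@@H]3[C@H](C(=O)N3CCN(c4ccc([N+](=O)[O-])cc4)CC3)C2)cc(C(=O)OC)c1` gives 437 nM, a gap beyond the scatter. For the measured compounds named here, the single step measured, a 2.3-fold lower number from compound 1 to compound 2 (0.36 log units; beyond the scatter), rests on drawn configuration alone the fact that one of compounds 1 and 2 is drawn with a defined configuration and the other without, at the place where they differ and leaves the aromatic part untouched. Compound 4 `Cc1nc2cc(C[C@H](C)CN3C[C@@H]4CCCC[C@@H]4[C@H](C(=O)N4CCN(c5ccc(F)c(F)c5)CC4)C3)ccc2o1` differs from compound 3 by methyl in place of hydrogen on an aromatic carbon. Going by the values given here, no measured step bears on this change, so the step of a 1.0-fold lower number from compound 3 to compound 4 (0.01 log units; within the scatter) is expected to stay within the scatter, in no particular direction. For compound 4 the estimate in this assay is 1600 nM, with a range from 600 nM to 4300 nM.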

Compound 4, dissociation constant: 1380 nM
Estimate against measurement, compound 4: 1.2-fold (0.06 log units) above, and the stated range covers the measured number.
By their numbers in this assay, from the lowest: compound 2; then compounds 1, 4 and 3 (each within the scatter of the next).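

Among the compounds shown here, the change from 1,3-benzoxazol-5-yl to 2-methyl-1,3-benzoxazol-5-yl gives a 1.2-fold lower number from compound 3 to compound 4 (0.07 log units; within the scatter) in this assay, the first reading at this position. Added methyl here therefore leaves the number within the scatter, and binding stays in the same weak range as compound 3. Nothing at hand bears on why this position behaves this way.

Open, going by these compounds, is whether a larger or charged group at the same place, such as an isopropyl, an amine or a carboxylic acid, would move the number beyond the scatter. Also open, on these data alone, is whether methyl on this carbon behaves alike with other aryl groups on the piperazine.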